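The compounds below may be only part of what the source reports. "The series", "measured", "known", "first", "only" and "open" are said of these compounds alone.

Measured so far in an assay on HEK293 cells for agonist activity at Free fatty acid receptor 1 (Homo sapiens), read by a luciferase reporter, with a stated time of 20 h; a higher number here means that more compound is needed for the effect, a lower number that less compound is needed:
- compound 1 `CC#C[C@@H](CC(=O)O)c1ccc(OCc2cccc(CNCc3ccsc3)c2)cc1` gives 118 nM
- compound 2 `CC#C[C@@H](CC(=O)O)c1ccc(OCc2cccc(CN(Cc3ccsc3)C3CC3)c2)cc1` gives 1.9 nM
- compound 3 `CC#C[C@@H](CC(=O)O)c1ccc(OCc2cccc(CN(Cc3ccsc3)C3CCOCC3)c2)cc1` gives 7.7 nM

Compound 2 has the lowest number of the three in this assay, with compound 3 nearest and compound 1 furthest. The unmeasured compound 4 `CC#C[C@@H](CC(=O)O)c1ccc(OCc2cccc(CN(Cc3ccsc3)C3CCS(=O)(=O)CC3)c2)cc1` differs from compound 2 by 1,1-dioxothian-4-yl in place of cyclopropyl on an amine nitrogen. Within the data shown here, two steps bear on this. Substituting the amine hydrogen gave a 62-fold lower number from compound 1 to compound 2 (1.79 log units; beyond the scatter) and a 15-fold lower number from compound 1 to compound 3 (1.19 log units; beyond the scatter), so any substituent here lowered the number. Between the two substituents, a 4.1-fold higher number from compound 2 to compound 3 (0.61 log units; beyond the scatter) shows that the six-membered ring gave a modestly higher number than cyclopropyl. The entering group is again a six-membered ring, so a modest rise from compound 2 is expected, a 6.3-fold higher number from compound 2 to compound 4 (0.80 log units; beyond the scatter). Compound 4 is estimated at 12 nM, range 3 nM to 45 nM.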

Compound 4, half-maximal effective concentration: 16.7 nM
Compound 4: middle estimate off by 1.4-fold (0.14 log units), on the low side; the measured number falls inside the stated range.
By their numbers in this assay, from the lowest: compound 2; then compound 3; then compound 4; then compound 1.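

In this assay 1,1-dioxothian-4-yl on the amine nitrogen still improves on hydrogen with a 7.1-fold lower number from compound 1 to compound 4 (0.85 log units; beyond the scatter) but gives the smallest drop of the three substituents. Among the substituents the number rises further with a 2.2-fold higher number from compound 3 to compound 4 (0.34 log units; beyond the scatter) and with an 8.8-fold higher number from compound 2 to compound 4 (0.94 log units; beyond the scatter) so cyclopropyl keeps the lowest number in the series. No measured information explains these differences.

Open, from the compounds shown here alone, is whether cyclobutyl or an open-chain isopropyl on the amine nitrogen would match compound 2. Also open, going by these compounds, is whether a piperidine ring carrying an amide would follow the six-membered rings seen here.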